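The source may hold more compounds than are shown below. What is called first, only, known or untested is meant among the compounds shown, and "the series" means these compounds.

Measured so far in a functional assay on A-375 cells (Homo sapiens) for cytotoxicity, read by CCK-8 assay, with a stated time of 24 h; on this read-out lower numbers stand for stronger inhibition and higher numbers for weaker inhibition:
compound 1, `COc1ccccc1Oc1c(N)nc(-c2ccc(F)cc2)nc1Cl`, gives 28200 nM
compound 2, `COc1ccccc1Oc1c(N)nc(-c2cccc(Cl)c2)nc1Cl`, gives 38300 nM
compound 3, `COc1ccccc1Oc1c(N)nc(-c2ccc(F)cc2)nc1OCCO`, gives 15900 nM

Compound 4, `COc1ccccc1Oc1c(N)nc(-c2cccc(Cl)c2)nc1OCCO`, is not yet measured. It differs from compound 3 by 3-chlorophenyl in place of 4-fluorophenyl on an aromatic carbon. The same kind of change separates compound 2 from compound 1, (3-chlorophenyl in place of 4-fluorophenyl on an aromatic carbon), where it gave a 1.4-fold higher number from compound 1 to compound 2 (0.13 log units; within the scatter). The two places are not identical: in compound 1 the changed carbon is meta to a chloro group and para to a group of 9 heavy atoms, in compound 3 it is meta to a 2-hydroxyethoxy group and para to a 2-methoxyphenoxy group. The cores themselves differ by 2-hydroxyethoxy in place of chloro on an aromatic carbon, which gave a 1.8-fold lower number from compound 1 to compound 3 (0.25 log units; within the scatter).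

Among the compounds with values here, for compound 4 a step of a 1.4-fold higher number from compound 3 to compound 4 (0.14 log units; within the scatter) is expected in this assay, resting on the single earlier instance, a 1.4-fold higher number from compound 1 to compound 2 (0.13 log units; within the scatter), and on nothing more. Compound 4 is thus estimated at 22000 nM, expected to lie between 10000 nM and 48000 nM.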

Compound 4, half-maximal inhibitory concentration: 30200 nM
Estimate against measurement, compound 4: 1.4-fold (0.14 log units) below; measured number inside the range.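

In this assay, 3-chlorophenyl in place of 4-fluorophenyl gives a 1.9-fold higher number from compound 3 to compound 4 (0.28 log units; within the scatter), and this change carries from one core to the other without a measurable difference: the same change on two cores in this assay, a 1.4-fold higher number (0.13 log units; within the scatter) from compound 1 to compound 2 and a 1.9-fold higher number (0.28 log units; within the scatter) from compound 3 to compound 4, 1.4-fold (0.15 log units) apart, within the scatter of two such steps. The other change, 2-hydroxyethoxy in place of chloro, gives a 1.3-fold lower number from compound 2 to compound 4 (0.10 log units; within the scatter), and it also carries across: the same change on two cores in this assay, a 1.8-fold lower number (0.25 log units; within the scatter) from compound 1 to compound 3 and a 1.3-fold lower number (0.10 log units; within the scatter) from compound 2 to compound 4, 1.4-fold (0.15 log units) apart, within the scatter of two such steps. Every step here lies within the scatter, so the four compounds show that the two changes combine consistently, but not that either change alters the read-out by itself.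

From the compounds shown here alone, it remains open whether an amine or a carboxylic acid in place of the 2-hydroxyethoxy group, or a longer chain there, would move the number beyond the scatter. Going by these compounds, whether the same steps hold on other cores also remains open.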